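This account rests on a few compounds, and the source may have more. Where it says the series, first, only, none or still open, it means among the compounds named here.

Among the measured compounds shown here, in an ADME assay on HCT-116 cells (Homo sapiens) for cytotoxicity, read by CellTiter-Glo, with a stated time of 72 h (a lower number here means a stronger inhibitor, a higher number a weaker inhibitor), no compound measured so far gives a number. Compound 1 `Cc1cc(C)c(S(=O)(=O)N2CCC(N3CCC(c4ccccc4)CC3)CC2)c(C)c1` reads > 5000 nM, which is a limit of the assay. Compound 2 `Cc1ccc(-c2ccccc2S(=O)(=O)N2CCC(N3CCC(C)CC3)CC2)cc1` reads > 5000 nM, again a limit. Compound 3 `CC1CCN(C2CCN(S(=O)(=O)c3ccccc3-c3ccc(C(F)(F)F)cc3)CC2)CC1` reads > 5000 nM, also a limit, so it offers only a limit as a starting point. Together these results come down to the limit of > 5000 nM in this assay, at which 3 of the 3 values shown sit.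

Compound 4 `CC1CCN(C2CCN(S(=O)(=O)c3ccccc3-c3ccc(Cl)cc3)CC2)CC1` differs from compound 3 in one place: chloro in place of trifluoromethyl on an aromatic carbon.

For the measured compounds named here, one measured step bears on this change, as it also swaps a group on an aromatic carbon: a step that the two limits leave unreadable from compound 2 to compound 3. Its size cannot be read, so it gives no direction. The expectation therefore rests on compound 3 and its value of > 5000 nM, and no change beyond the scatter is expected. The expected result is a step that the limit leaves unreadable from compound 3 to compound 4. For compound 4 the estimated value is 7000 nM, with an expected range from 3000 nM to 20000 nM.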

Compound 4, half-maximal inhibitory concentration: > 5000 nM
Compound 4 gave a limit, no number; the forecaster's own chance of this, stated with the estimate: 85%; the middle value is on the limit's open side.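

In this assay compound 4 gives > 5000 nM, which is a limit and not a number, so its steps from compound 2 and compound 3 cannot be read. The compounds shown leave open how they rank against one another and which change would give a readable number, as all share one result: the limit of > 5000 nM in this assay, at which 4 of the 4 values shown sit.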